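Adding a hydroxy to the polyhydroxyphenyl series

The source may hold more compounds than are shown below. What is called first, only, known or untested is meant among the compounds shown, and "the series" means these compounds.

Measured in an ADME assay on MDCK cells (Canis lupus familiaris) for cytotoxicity; on this read-out lower numbers stand for higher toxicity in this test and higher numbers for lower toxicity in this test:
- compound 1 `O=[N+]([O-])C1=NNc2nc(C(F)(F)F)nn2C1c1c(O)cc(O)cc1O`: 252000 nM
- compound 2 `O=[N+]([O-])C1=NNc2nc(C(F)(F)F)nn2C1c1ccc(O)cc1O`: 108000 nM

For the measured compounds named here, compound 2 stands lowest of the two numbers, and compound 1 is the only neighbour for comparison. The next compound to read is compound 3 `O=[N+]([O-])C1=NNc2nc(C(F)(F)F)nn2C1c1ccc(O)c(O)c1O`, not yet measured in this assay. Its change from compound 2 is hydroxy in place of hydrogen on an aromatic carbon.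

Going by the values given here, one measured step bears on this change: a 2.3-fold lower number from compound 1 to compound 2 (0.37 log units; beyond the scatter). That step is modest and is hydrogen in place of hydroxy on an aromatic carbon. Read in reverse, it links an added hydroxy to a higher number. However, the carbon concerned in that pair is not the one that changes in compound 3, and a single pair sets no pattern. A modest upward step is therefore expected at most, and one within the scatter is quite possible.

The estimate for compound 3 is 150000 nM, with an expected range of 65000 nM to 340000 nM. The expected change is a 1.4-fold higher number from compound 2 to compound 3 (0.14 log units; within the scatter).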

Compound 3, half-maximal cytotoxic concentration: 67000 nM
Estimate against measurement, compound 3: 2.2-fold (0.35 log units) above, within the range that was stated.
By their numbers in this assay, from the lowest: compounds 3 and 2 (each within the scatter of the next); then compound 1.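

In this assay, a hydroxy entering on the aromatic carbon ortho to two hydroxy groups and meta to a large group gives a 1.6-fold lower number from compound 2 to compound 3 (0.21 log units; within the scatter) and so does not separate compound 3 from compound 2. The earlier pair, which concerns a different carbon, gave a 2.3-fold lower number from compound 1 to compound 2 (0.37 log units; beyond the scatter) and linked an added hydroxy to a higher number on this read-out, but that link does not extend to the carbon changed here. With only these two steps, the series shows that the same change can read differently at two carbons of this ring, and no measurement is available that accounts for the difference.

From the compounds shown here alone, whether a group other than hydroxy on this same carbon, such as a methoxy, an amine or a carboxylic acid, would move the number beyond the scatter remains open. Also open, going by these compounds, is whether a hydroxy on this carbon reads the same without the two neighbouring hydroxy groups, or when the trifluoromethyl of the shared core gives way to a longer chain.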